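Notes on replacing the oxadiazolone ring of compound 3

The compounds below may be only part of what the source reports. "The series", "measured", "known", "first", "only" and "open" are said of these compounds alone.

Measured so far:
compound 1 `CC(C)C(Cc1nnc[nH]1)c1ccc(-c2ccc3cccc(F)c3c2)[nH]c1=O` — in an ADME assay on microsomes from liver (Rattus norvegicus) for metabolic stability (on this read-out lower numbers stand for a shorter-lived compound and higher numbers for a longer-lived compound), compound 1 gives 0.1 h
compound 2 `CC(C)C(c1ccc(-c2ccc3cccc(F)c3c2)[nH]c1=O)N1CCN/C1=N\C#N` — in this assay compound 2 gives 0.327 h
compound 3 `CC(C)C(Cc1noc(=O)[nH]1)c1ccc(-c2ccc3cccc(F)c3c2)[nH]c1=O` — in this assay compound 3 gives > 3 h, which is a limit of the assay and not a number.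

Compound 3 stands highest of the three: both steps toward it were rises, an at least 30-fold higher number from compound 1 to compound 3 (1.47 log units; beyond the scatter) and an at least 9.1-fold higher number from compound 2 to compound 3 (0.96 log units; beyond the scatter), and it sits at the limit of > 3 h in this assay, at which 1 of the 3 values shown sits. Compound 4 `CC(C)C(/C=C1\CCNC1=O)c1ccc(-c2ccc3cccc(F)c3c2)[nH]c1=O` differs from compound 3 by a group of 7 heavy atoms (5 carbon, 1 nitrogen, 1 oxygen; one five-membered non-aromatic ring with 1 hetero atom) in place of a group of 7 heavy atoms (3 carbon, 2 nitrogen, 2 oxygen; one five-membered aromatic ring with 3 hetero atoms), on a saturated chain carbon bound to an aromatic carbon and a saturated chain carbon. Both steps into compound 3 bear on this change, since each put the five-membered aromatic ring with 3 hetero atoms in place of another group and the number rose; taking that ring out again in compound 4 is therefore expected to lower the number, from a starting point known only as a limit. For compound 4 the expected step is an at least 6.0-fold lower number from compound 3 to compound 4 (0.77 log units; beyond the scatter), and its estimated value is 0.5 h with a range from 0.15 h to 2 h.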

Compound 4, half-life: 0.345 h
Estimate against measurement, compound 4: 1.4-fold (0.16 log units) above; the measured number falls inside the stated range.
By their numbers in this assay, from the lowest: compound 1; then compounds 2 and 4 (each within the scatter of the next). At a limit, above all of these: compound 3.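

Replacing the oxadiazolone-type ring at this place does not keep the long half-life in this assay, with an at least 8.6-fold lower number from compound 3 to compound 4 (0.93 log units; beyond the scatter). The five-membered non-aromatic rings of the two compounds are not separated, with a 1.1-fold higher number from compound 2 to compound 4 (0.02 log units; within the scatter), yet an aromatic ring alone is not sufficient, with a 3.5-fold higher number from compound 1 to compound 4 (0.54 log units; beyond the scatter), since compound 1 carries one and stands lowest. The reading for compound 3 is a limit, not a number: the limit of > 3 h in this assay, at which 1 of the 4 values shown sits.

From the compounds shown here alone, whether a carboxylic acid or a tetrazole at this place would reach that limit stays open. So does the true half-life of compound 3.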